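The source may report more compounds than this note shows. Statements on the series, on what has been measured and on what is new or still open speak of the compounds shown alone.

Measured compounds:
- compound 1, `CCCCC#Cc1cc([C@@H]2O[C@H](CO)[C@@H](O)[C@H]2O)n2ncnc(N)c12`: 200 nM
- compound 2, `Nc1ncnn2c([C@@H]3O[C@H](CO)[C@@H](O)[C@H]3O)cc(C#Cc3cccs3)c12`: 50100 nM
- compound 3, `Cc1ccccc1-c1cc([C@@H]2O[C@H](CO)[C@@H](O)[C@H]2O)n2ncnc(N)c12`: 66000 nM

In a functional assay on Z-138 cells (Homo sapiens) for antiproliferative activity, with a stated time of 72 h (on this read-out higher numbers stand for weaker inhibition and lower numbers for stronger inhibition), compound 2 gives 50100 nM, the second highest of the three numbers. Its nearest neighbour is compound 3, which in this assay gives 66000 nM; the step of a 1.3-fold higher number from compound 2 to compound 3 (0.12 log units; within the scatter) lies within the scatter. Its furthest neighbour is compound 1, which in this assay gives 200 nM, and the step of a 250-fold higher number from compound 1 to compound 2 (2.40 log units; beyond the scatter) is large.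

The unmeasured compound 4, `Nc1ncnn2c([C@@H]3O[C@H](CO)[C@@H](O)[C@H]3O)cc(-c3ccsc3)c12`, differs from compound 2 in one place: thiophen-3-yl in place of 2-(thiophen-2-yl)ethynyl on an aromatic carbon.

The step that bears most directly on this change is a 1.3-fold higher number from compound 2 to compound 3 (0.12 log units; within the scatter), where an aryl group directly on the aromatic carbon replaced the 2-(thiophen-2-yl)ethynyl group with no shift beyond the scatter. The large loss in a 330-fold higher number from compound 1 to compound 3 (2.52 log units; beyond the scatter) started from the butyl alkyne of compound 1, not from the thiophene alkyne of compound 2, so it does not speak against compound 4 staying near compound 2. The step of a 1.1-fold higher number from compound 2 to compound 4 (0.04 log units; within the scatter) is therefore expected to be within the scatter, in no particular direction. Compound 4 is estimated to give 55000 nM in this assay, with a range from 20000 nM to 150000 nM.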

Compound 4, half-maximal inhibitory concentration: 43500 nM
Estimate against measurement, compound 4: 1.3-fold (0.10 log units) above, and the stated range covers the measured number.
By their numbers in this assay, from the lowest: compound 1; then compounds 4, 2 and 3 (each within the scatter of the next).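

In this assay, thiophen-3-yl on this aromatic carbon gives a 1.2-fold lower number from compound 2 to compound 4 (0.06 log units; within the scatter), and the comparison with the 2-methylphenyl compound gives a 1.5-fold lower number from compound 3 to compound 4 (0.18 log units; within the scatter), so a thiophene set directly on the ring, without the triple bond, cannot be told apart from either of the other two aromatic substituents. Against the hex-1-yn-1-yl group the same change gives a 220-fold higher number from compound 1 to compound 4 (2.34 log units; beyond the scatter), which leaves compound 1 alone at the low end and shows that, among these four compounds, all three with an aromatic ring in this place sit together whether or not a triple bond links that ring to the core. No measurement at hand explains this split.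

On these data alone, it remains open whether a saturated hexyl chain on this aromatic carbon would stay near compound 1 or join the aromatic groups, a comparison that would separate the contribution of the triple bond from that of the chain. Also open, as far as these compounds go, is how a terminal amine or hydroxyl on the butyl end of the alkyne would read in this assay.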